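Indolyl in Place of Fluorophenyl: An Expected Cytotoxicity Shift

The compounds below may be only part of what the source reports. "The series", "measured", "known", "first", "only" and "open" are said of these compounds alone.

Compound 1, `O=C1C(=Cc2ccc(F)cc2)C(=O)N(c2ccc(Cl)cc2)N1c1ccc(Cl)cc1`: 31400 nM
Compound 2, `O=C1C(=Cc2ccc(F)cc2F)C(=O)N(c2ccc(Cl)cc2)N1c1ccc(Cl)cc1`: 22000 nM
Compound 3, `O=C1C(=C/C=C/c2ccccc2)C(=O)N(c2ccc(Cl)cc2)N1c1ccc(Cl)cc1`: 9400 nM

The three measured compounds share one core and differ only in the group attached to the exocyclic double bond. In a functional assay on MCF7 cells (Homo sapiens) for cytotoxicity, read by MTT assay, with a stated time of 72 h (on this read-out lower numbers stand for stronger inhibition and higher numbers for weaker inhibition), compound 1 gives the highest number of the three. Compound 2 is within the scatter of it, as seen in a 1.4-fold lower number from compound 1 to compound 2 (0.15 log units; within the scatter), whereas compound 3 shows a modest step in a 3.3-fold lower number from compound 1 to compound 3 (0.52 log units; beyond the scatter).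

Compound 4, `O=C1C(=Cc2c[nH]c3ccccc23)C(=O)N(c2ccc(Cl)cc2)N1c1ccc(Cl)cc1`, has not been measured. It differs from compound 1 thus: 1H-indol-3-yl in place of 4-fluorophenyl on a double-bonded chain carbon bound to a double-bonded ring carbon.

The step from compound 1 to compound 2 is of little help, since it merely adds a fluoro. The step of a 3.3-fold lower number from compound 1 to compound 3 (0.52 log units; beyond the scatter) is the closer guide, as it also exchanges the 4-fluorophenyl for a larger group at the same place, and it gave only a modest gain. For the measured compounds named here, a comparable, modest lowering is therefore anticipated, though the indolyl is a new group and the data give no direct precedent.

Compound 4 is expected to give about 15000 nM, with a range from 5000 nM to 40000 nM. This estimate corresponds to an expected step of a 2.1-fold lower number from compound 1 to compound 4 (0.32 log units; beyond the scatter).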

Compound 4, half-maximal inhibitory concentration: 34200 nM
For compound 4 the middle estimate is 2.3-fold (0.36 log units) below the measured one, within the range that was stated.
By their numbers in this assay, from the lowest: compound 3; then compounds 2, 1 and 4 (each within the scatter of the next).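

In this assay, 1H-indol-3-yl, which brings a second aromatic ring and a hydrogen-bond donor, cannot be told apart from the 4-fluorophenyl it replaces (a 1.1-fold higher number from compound 1 to compound 4 (0.04 log units; within the scatter)). It also cannot be told apart from the 2,4-difluorophenyl of compound 2 (a 1.6-fold higher number from compound 2 to compound 4 (0.19 log units; within the scatter)), so a larger group at this place does not by itself repeat the result of compound 3. Among the groups compared on this double-bonded chain carbon, 2-phenylethenyl remains the one that stands apart, here from 1H-indol-3-yl (a 3.6-fold higher number from compound 3 to compound 4 (0.56 log units; beyond the scatter)).

The compounds shown leave open whether a longer chain ending in a phenyl ring, or an amine or a carboxylic acid on the aromatic ring, would take the number lower at this place. No measurement shown here accounts for the difference between these groups.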